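From Bromo to Trifluoromethyl: What to Expect of Compound 4

The source may report more compounds than this note shows. Statements on the series, on what has been measured and on what is new or still open speak of the compounds shown alone.

Of the compounds shown here, three built on one shared core have been tested in a functional assay on NCI-H460 cells (Homo sapiens) for antiproliferative activity; a higher number here means a weaker inhibitor, a lower number a stronger inhibitor. Compound 1 `COc1ccc2c(c1)[nH]c1c2c2c(c3c4cccc5c4n(c13)CC(CO)C5)C(=O)NC2=O` gives 1960 nM, compound 2 `O=C1NC(=O)c2c1c1c3ccccc3ccc1c1c2c2cccc3c2n1C(CO)CC3` gives 540 nM, and compound 3 `O=C1NC(=O)c2c1c1c3ccc(Br)cc3[nH]c1c1c2c2cccc3c2n1CC(CO)C3` gives 360 nM. Compound 3 thus has the lowest of the three numbers; its gap to compound 2 lies within the scatter of repeated measurements, while its gap to compound 1 lies beyond it. Within the data shown here, the one step between compounds differing in a single place runs a 5.4-fold lower number from compound 1 to compound 3 (0.74 log units; beyond the scatter), a modest change.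

Compound 4 `O=C1NC(=O)c2c1c1c3ccc(C(F)(F)F)cc3[nH]c1c1c2c2cccc3c2n1CC(CO)C3` differs from compound 3 in one place: trifluoromethyl in place of bromo on an aromatic carbon. Among the measured compounds shown here, no measured pair sets a bromo against a trifluoromethyl, so the step from compound 1 to compound 3 bears on the question only in showing that an exchange of the group at this position shifted the number by a modest amount. For the measured compounds named here, with no step addressing this exchange directly, the expectation is a number near that of compound 3, and the step of a 1.3-fold higher number from compound 3 to compound 4 (0.10 log units; within the scatter) is not expected to reach beyond the scatter. Compound 4 is therefore estimated at 450 nM, within a range from 150 nM to 1400 nM.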

Compound 4, half-maximal inhibitory concentration: 690 nM
For compound 4 the middle estimate is 1.5-fold (0.19 log units) below the measured one, and the stated range covers the measured number.
By their numbers in this assay, from the lowest: compounds 3, 2 and 4 (each within the scatter of the next); then compound 1.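

In this assay, among these compounds, this exchange is the first direct comparison of bromo and trifluoromethyl at this position, and a 1.9-fold higher number from compound 3 to compound 4 (0.28 log units; within the scatter) shows that a group of 4 heavy atoms can replace one of 1 heavy atom without a change beyond the scatter. The methoxy comparison now has two members: alongside a 5.4-fold lower number from compound 1 to compound 3 (0.74 log units; beyond the scatter) stands a 2.8-fold lower number from compound 1 to compound 4 (0.45 log units; beyond the scatter), so among the three groups tried on this aromatic carbon, methoxy is the one set apart, while bromo and trifluoromethyl cannot be told apart. No measurement at hand explains why methoxy differs from the other two groups.

Among the compounds shown here, with only three groups compared here, it remains open whether the gap belongs to methoxy alone or extends to other oxygen-linked groups such as a hydroxyl or an ethoxy. From the compounds shown here alone, how an amine, a carboxylic acid or a plain hydrogen at this position would compare also remains open, and a plain hydrogen would show whether any of these groups moves the number from that of the bare core.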